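Pyridin-2-yl to 3-methyl-1,2-oxazol-5-yl: expected solubility

A few compounds are considered here, and "the series" means these few. Any claim that something is new, unique, unknown or untested is made for them only; others in the source may bear on it.

Measured so far:
compound 1 `O=C(Nc1ccc(F)c(C(F)(F)F)c1)Nc1ccccn1` — 1.6 ug/mL
compound 2 `N#Cc1ccc(NC(=O)Nc2ccc(F)c(C(F)(F)F)c2)cc1` — < 1.6 ug/mL
compound 3 `NC(=O)c1ccccc1NC(=O)Nc1ccc(F)c(C(F)(F)F)c1` — 1.6 ug/mL

Of the compounds shown here, three sharing one core have been measured in a physicochemical assay for solubility, read by nephelometry, measured as kinetic solubility, at pH 2; on this read-out higher numbers stand for higher solubility and lower numbers for lower solubility. Compound 1 gives 1.6 ug/mL. Compound 3 gives 1.6 ug/mL, level with compound 1 at the digits recorded, within the scatter. For compound 2 this assay reports only a limit, < 1.6 ug/mL, and not a number. Compound 1 therefore stands level with its nearest neighbour, compound 3, and one further value in the set is a limit, as the limit of < 1.6 ug/mL in this assay, at which 1 of the 3 values shown sits, records.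

Compound 4 `Cc1cc(NC(=O)Nc2ccc(F)c(C(F)(F)F)c2)on1` has not yet been measured in this assay. It differs from compound 1 in a single place: 3-methyl-1,2-oxazol-5-yl in place of pyridin-2-yl on an amide-type nitrogen. Within the data shown here, no measured step between compounds that differ in one place exists in this set, so the expected step of no change at the digits printed from compound 1 to compound 4 (within the scatter) is none beyond the scatter. Compound 4 is accordingly estimated at 1.6 ug/mL, with a range from 0.8 ug/mL to 4 ug/mL.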

Compound 4, solubility: 12.5 ug/mL
Compound 4: the middle estimate sits 7.8-fold (0.89 log units) below what was measured, outside the stated range (above it).
By their numbers in this assay, from the lowest: compounds 1 and 3 (each within the scatter of the next); then compound 4.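

In this assay, among these compounds, putting 3-methyl-1,2-oxazol-5-yl in place of pyridin-2-yl on an amide-type nitrogen gives a 7.8-fold higher number from compound 1 to compound 4 (0.89 log units; beyond the scatter), the first measured step in this set between compounds that differ in one place. It shows that this position can move the read-out, even in an exchange that leaves the count of heavy atoms unchanged. The earlier compounds offered no such step, and one of the values in the set is a limit and not a number: the limit of < 1.6 ug/mL in this assay, at which 1 of the 4 values shown sits.

Which part of the change carries the step stays open, since this single pair cannot separate the ring size, the hetero atoms and the methyl group. Also open, as far as these compounds go, is how the read-out would respond to an amine or a carboxylic acid on that ring, or to a longer chain in place of the methyl.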